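Halogenated phenyl on the core of compound 3

A few compounds are considered here, and "the series" means these few. Any claim that something is new, unique, unknown or untested is made for them only; others in the source may bear on it.

Three compounds have been measured in a functional assay on HT-29 cells (Homo sapiens) for antiproliferative activity, read by MTT assay, with a stated time of 72 h; a lower number here means a stronger inhibitor, a higher number a weaker inhibitor:

Compound 1, `O=C(Nc1ccc(Oc2ccnc3[nH]ccc23)cc1)c1cc2cccnc2n(-c2ccccc2)c1=O`, gives 290 nM in this assay.
Compound 2, `O=C(Nc1ccc(Oc2ccnc3[nH]ccc23)cc1)c1cc2cccnc2n(-c2ccc(C(F)(F)F)cc2Cl)c1=O`, gives 2160 nM in this assay.
Compound 3, `Cn1ccc2c(Oc3ccc(NC(=O)c4cc5cccnc5n(-c5ccccc5)c4=O)cc3)ccnc21`, gives 620 nM in this assay.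

Compound 3 stands second highest of the three numbers, with a 2.1-fold higher number from compound 1 to compound 3 (0.33 log units; beyond the scatter) separating it from compound 1, while compound 2 sits further off with a higher number still. Compound 4, `Cn1ccc2c(Oc3ccc(NC(=O)c4cc5cccnc5n(-c5ccc(Br)cc5F)c4=O)cc3)ccnc21`, has not yet been measured. It differs from compound 3 in one place: 4-bromo-2-fluorophenyl in place of phenyl on an aromatic nitrogen.

Going by the values given here, one measured step bears on this change. Between compound 1 and compound 2 the same phenyl was replaced by a phenyl carrying a chlorine and a trifluoromethyl group, and the result was a 7.4-fold higher number from compound 1 to compound 2 (0.87 log units; beyond the scatter). The change from compound 3 to compound 4 is of the same kind, a phenyl on the aromatic nitrogen exchanged for one bearing two halogens, so a weakening of similar size is expected, although a bromine and a fluorine are not a chlorine and a trifluoromethyl, and the step may come out smaller. For compound 4 the expected step is a 4.0-fold higher number from compound 3 to compound 4 (0.61 log units; beyond the scatter), and its estimated value is 2500 nM, with a range from 1000 nM to 6500 nM.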

Compound 4, half-maximal inhibitory concentration: 2580 nM
Estimate against measurement, compound 4: 1.0-fold (0.01 log units) below; measured number inside the range.
By their numbers in this assay, from the lowest: compound 1; then compound 3; then compounds 2 and 4 (each within the scatter of the next).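

In this assay, a 4.2-fold higher number from compound 3 to compound 4 (0.62 log units; beyond the scatter) shows that the loss seen earlier with a substituted phenyl on this aromatic nitrogen also appears on the methylated compound, alongside a 7.4-fold higher number from compound 1 to compound 2 (0.87 log units; beyond the scatter). It also shows that a trifluoromethyl group and a chlorine are not needed for such a loss, since 4-bromo-2-fluorophenyl, which carries neither, also gives a higher number than plain phenyl. In both measured pairs, then, plain phenyl gives the lower number, and no compound shown goes against this; no measurement is available that explains the loss at this position.

As far as these compounds go, compound 4 carries its bromine and fluorine together, so the share of the step belonging to each halogen remains unknown, and a phenyl bearing only one of them would be needed to separate the two. Also open, from the compounds shown here alone, is whether any replacement at this position can give a lower number than plain phenyl, for example a phenyl carrying an amine or a carboxylic acid, or a simple methyl in place of the whole ring.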